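Half-life in the rat after swapping one small aromatic ring

The source may hold more compounds than are shown below. What is called first, only, known or untested is meant among the compounds shown, and "the series" means these compounds.

Measured compounds:
Compound 1, `CCCC[C@H](NC(=O)OC(C(C)C)C(C)C)C(=O)C(=O)NCc1ccccn1`: 1.28 h
Compound 2, `CCCC[C@H](NC(=O)OC(C(C)C)C(C)C)C(=O)C(=O)NCc1nnco1`: 0.35 h

The two measured compounds share one core and differ only in the ring at the end. In an in vivo ADME assay on the whole organism for pharmacokinetics, with Rattus norvegicus as the target (a higher number here means that the compound lasts longer, a lower number that the compound disappears faster), compound 1 gives 1.28 h, and compound 2 gives 0.35 h. The step of a 3.7-fold lower number from compound 1 to compound 2 (0.56 log units; beyond the scatter) is the only one so far, and it leaves compound 2 with the lowest of the two numbers.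

Compound 3, `CCCC[C@H](NC(=O)OC(C(C)C)C(C)C)C(=O)C(=O)NCc1ccno1`, is the next member: 1,2-oxazol-5-yl in place of 1,3,4-oxadiazol-2-yl on a saturated chain carbon bound to an amide-type nitrogen. For the measured compounds named here, only the step from compound 1 to compound 2 bears on this change, and it moved the number down by a modest amount when a ring with more hetero atoms came in. Because a 3.7-fold lower number from compound 1 to compound 2 (0.56 log units; beyond the scatter) was beyond the scatter, some movement in the opposite direction is plausible for a ring with fewer hetero atoms, but a step within the scatter is the expected outcome, so the estimated step is a 1.4-fold higher number from compound 2 to compound 3 (0.15 log units; within the scatter). Compound 3 is therefore expected to give about 0.5 h in this assay, with a range from 0.25 h to 1 h.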

Compound 3, half-life in the Rattus norvegicus assay: 0.867 h
Compound 3: the middle estimate sits 1.7-fold (0.24 log units) below what was measured; measured number inside the range.
By their numbers in the Rattus norvegicus assay, from the lowest: compound 2; then compounds 3 and 1 (each within the scatter of the next).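

In the Rattus norvegicus assay, a five-membered ring does not by itself bring a short half-life: the move to 1,2-oxazol-5-yl gives a 2.5-fold higher number from compound 2 to compound 3 (0.39 log units; beyond the scatter), and against the pyridin-2-yl of compound 1 there is a 1.5-fold lower number from compound 1 to compound 3 (0.17 log units; within the scatter). In a physicochemical assay for lipophilicity (a higher number here means a more lipophilic compound, a lower number a more polar compound), compound 2 gives 3.4 and compound 3 gives 5. The same change that lengthens the half-life also makes the compound more lipophilic, so lipophilicity may contribute to the longer half-life, although a single pair of compounds cannot establish this: the measured partition coefficient of compound 2, 3.4, and of compound 3, 5, a number 1.60 log units higher (beyond the scatter)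

The compounds shown leave open whether half-life and lipophilicity would keep moving together in other rings on a saturated chain carbon bound to an amide-type nitrogen, such as a phenyl or a thiazole. They also do not show what an added amine or carboxylic acid on the ring would do to the half-life, or which part of the molecule governs how quickly it disappears from the rat.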